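Reversing the enone and swapping the aryl substituent on the core

The compounds below may be only part of what the source reports. "The series", "measured", "known", "first", "only" and "open" are said of these compounds alone.

Of the compounds shown here, three sharing one core have been measured in a functional assay on DU-145 cells (Homo sapiens) for antiproliferative activity, read by MTT assay, with a stated time of 24 h; a lower number here means a stronger inhibitor, a higher number a weaker inhibitor. Compound 1 `COc1ccc(-c2cc(/C=C/C(=O)c3cc(OC)c(OC)c(OC)c3)nc3cc(-c4ccccc4)nn23)cc1OC` gives 8300 nM, compound 2 `COc1cc(-c2cc(C(=O)/C=C/c3ccc(Cl)cc3)nc3cc(-c4ccccc4)nn23)cc(OC)c1OC` gives 19500 nM, and compound 3 `COc1ccc(-c2cc(C(=O)/C=C/c3ccc(Cl)cc3)nc3cc(-c4ccccc4)nn23)cc1OC` gives 22400 nM. For the measured compounds named here, compound 3 holds the highest number of the three; its nearest neighbour is compound 2, and the only step recorded between two compounds differing in one place, a 1.1-fold higher number from compound 2 to compound 3 (0.06 log units; within the scatter), is small. Compound 4 `COc1ccc(-c2cc(/C=C/C(=O)c3ccc(C)cc3)nc3cc(-c4ccccc4)nn23)cc1OC` differs from compound 3 by 2-((4-methylphenyl)carbonyl)ethenyl in place of (2-(4-chlorophenyl)ethenyl)carbonyl on an aromatic carbon. Going by the values given here, no measured step covers this change; compound 1, which carries an enone in the same orientation as compound 4 but a different aryl group, shows a lower number than compound 3. Compound 4 is therefore expected to come in somewhat lower, by about a 1.7-fold lower number from compound 3 to compound 4 (0.24 log units; within the scatter), giving an estimated 13000 nM within 4500 nM to 38000 nM.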

Compound 4, half-maximal inhibitory concentration: 26800 nM
The estimate for compound 4 lay 2.1-fold (0.31 log units) below the measured number; the measured number falls inside the stated range.
By their numbers in this assay, from the lowest: compound 1; then compounds 2, 3 and 4 (each within the scatter of the next).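

In this assay the exchange of (2-(4-chlorophenyl)ethenyl)carbonyl for 2-((4-methylphenyl)carbonyl)ethenyl at this position changes little (a 1.2-fold higher number from compound 3 to compound 4 (0.08 log units; within the scatter)), so the enone orientation shared by compound 1 and compound 4 does not by itself give the lower number. The aryl group on the carbonyl does matter: 4-methylphenyl in place of 3,4,5-trimethoxyphenyl gives a real step (a 3.2-fold higher number from compound 1 to compound 4 (0.51 log units; beyond the scatter)). Nothing available here explains either step. Still open, from the compounds shown here alone, is whether that aryl group would tolerate an amine or a carboxylic acid.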